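The compounds below may be only part of what the source reports. "The series", "measured", "known", "first", "only" and "open" are said of these compounds alone.

Measured compounds:
- compound 1 `Cc1nc(-c2cccs2)sc1COc1ccc2c(c1)OCC2CC(=O)O` — "not determined" (no result reported) in a functional assay on CHO cells for agonist activity at Free fatty acid receptor 1 (Homo sapiens), read by FLIPR and calcium flux; a higher number here means that more compound is needed for the effect, a lower number that less compound is needed
- compound 2 `Cc1nc(-c2ccsc2)sc1COc1ccc2c(c1)OCC2CC(=O)O` — 68.5 nM in this assay
- compound 3 `Cc1ccccc1-c1nc(C)c(COc2ccc3c(c2)OCC3CC(=O)O)s1` — "not determined" (no result reported) in this assay

Compound 3 stands without a number: in this assay no half-maximal effective concentration was reported for it, and compound 1 is in the same position. Among the measured compounds shown here, the only number comes from compound 2, which gives 68.5 nM in this assay.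

Compound 4 `Cc1nc(-c2ccc(Cl)cc2)sc1COc1ccc2c(c1)OCC2CC(=O)O` arises from compound 3 by a single change, (4-chlorophenyl in place of 2-methylphenyl on an aromatic carbon). Since neither end of this change is anchored by a number for compound 3, no step size can be taken from the data, and no direction can be read from it. The expectation rests on compound 2 alone, whose value of 68.5 nM in this assay shows what an aryl group on that carbon of the shared core can deliver.

For compound 4 a half-maximal effective concentration near 60 nM in this assay is expected, with an estimated range from 15 nM to 250 nM.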

Compound 4, half-maximal effective concentration: 85.6 nM
Estimate against measurement, compound 4: 1.4-fold (0.15 log units) below; measured number inside the range.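

Compound 4 gives the series its first number for a six-membered aromatic ring of carbon only on this aromatic carbon of the five-membered aromatic ring. In this assay the change to 4-chlorophenyl in place of thiophen-3-yl gives a 1.2-fold higher number from compound 2 to compound 4 (0.10 log units; within the scatter) and so leaves the read-out where it was, which shows that this carbon accepts either group without a step beyond the scatter. No measured finding among these compounds explains why the two groups read alike.

The steps that start from compound 1 or compound 3 cannot be read, so thiophen-2-yl and 2-methylphenyl remain unplaced against 4-chlorophenyl. Also open, going by these compounds, is how this carbon would respond to a phenyl bearing an amine or a carboxylic acid, or to a longer chain in place of the aryl group.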